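Replacing amino with 4-methylpiperazin-1-yl on compound 3

The compounds below may be only part of what the source reports. "The series", "measured", "known", "first", "only" and "open" are said of these compounds alone.

Of the compounds shown here, three have so far been measured in a physicochemical assay for solubility, read by HPLC, using the shake flask method, in phosphate buffer, with a stated time of 20 h, at pH 6.5; a higher number here means a more soluble compound, a lower number a less soluble compound. Compound 1 (`CN1CCN(c2nccc3nc(-c4ccc(F)c(F)c4)[nH]c23)CC1`) gives 130000 nM, compound 2 (`Fc1ccc(-c2nc3c(N4CCCNCC4)nccc3[nH]2)cc1F`) gives 165000 nM, and compound 3 (`NC1CCN(c2nccc3[nH]c(-c4cccc(OC(F)(F)F)c4)nc23)CC1`) gives 200000 nM. Compound 3 stands within the scatter of both other compounds, so these numbers set no order among the three. For the measured compounds named here, the measured compounds differ from one another in more than one place, and the data therefore hold no direct precedent for a single change.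

Compound 4 (`CN1CCN(C2CCN(c3nccc4[nH]c(-c5cccc(OC(F)(F)F)c5)nc34)CC2)CC1`) departs from compound 3 in one place: 4-methylpiperazin-1-yl in place of amino on a saturated ring carbon. The new group sits three ring bonds from the ring nitrogen.

No step beyond the scatter is expected in this assay, in either direction. Going by the values given here, the only guide is the measured set, where compound 1 at 130000 nM and compound 2 at 165000 nM remain within the scatter of compound 3 at 200000 nM, despite their different groups on the shared core. The estimated change is a 1.2-fold lower number from compound 3 to compound 4 (0.07 log units; within the scatter), which would stay within the scatter. For compound 4 the estimated value is 170000 nM, with an expected range from 90000 nM to 240000 nM.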

Compound 4, solubility: 190000 nM
Estimate against measurement, compound 4: 1.1-fold (0.05 log units) below; low and high end bracket the measured number.
By their numbers in this assay, from the lowest: compounds 1, 2, 4 and 3 (each within the scatter of the next).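

In this assay, for the compounds shown here, the only step between compounds that differ in one place is a 1.1-fold lower number from compound 3 to compound 4 (0.02 log units; within the scatter) for 4-methylpiperazin-1-yl in place of amino on a saturated ring carbon, three ring bonds from the ring nitrogen. The exchange is large in build, since 1 heavy atom leaves and 7 heavy atoms enter, bringing one six-membered non-aromatic ring with 2 hetero atoms and taking the count from 1 hydrogen-bond donor to 0 hydrogen-bond donors, and still the pair stays within the scatter in this read-out of solubility. No measurement at hand accounts for the two groups reading alike.

The compounds shown leave open whether a carboxylic acid, a morpholine or a longer alkyl chain on this same saturated ring carbon would also stay within the scatter of compound 3. Going by these compounds alone, with only this one pair, they also leave open whether the same exchange would read alike with a group other than trifluoromethoxy on the aromatic ring of compound 3.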